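The source may report more compounds than this note shows. Statements on the series, on what has been measured and on what is new or still open speak of the compounds shown alone.

Compound 1 `Fc1cccc(F)c1Cc1cnc(Nc2ccc(Oc3cccnc3)c(Cl)c2)o1` gives 16000 nM in an ADME assay on MT2 cells (Homo sapiens) for cytotoxicity, read by MTT assay; a lower number here means that less compound is tolerated, a higher number that more compound is tolerated.
Compound 2 `Fc1cccc(F)c1Cc1cnc(Nc2ccc(-c3cccnc3)c(Cl)c2)o1` gives 8900 nM in this assay.
Compound 3 `Fc1cccc(F)c1Cc1cnc(Nc2ccc(COc3ccncc3)cc2)o1` gives only a limit in this assay, namely > 100000 nM.

Compound 3 therefore stands at the edge of what was measured: its value is a limit, (the limit of > 100000 nM in this assay, at which 1 of the 3 values shown sits), and not a number, so it is known only that the tolerated concentration is not lower than that limit. Compound 4 `Fc1cccc(F)c1Cc1cnc(Nc2ccc(COc3ccncc3)c(Cl)c2)o1` differs from compound 3 in one place: chloro in place of hydrogen on an aromatic carbon. For the measured compounds named here, no measured step makes this same change. Going by the values given here, the one measured step, a 1.8-fold lower number from compound 1 to compound 2 (0.25 log units; within the scatter), concerns a different part of the molecule and stays within the scatter, so it gives little guidance. Compounds 1 and 2 both carry a chloro group and give numbers in this assay, while compound 3 lacks it and gives a limit; that is what the values show, nothing more. Compound 4 is therefore expected to stay close to compound 3, with a step of an at least 1.4-fold lower number from compound 3 to compound 4 (0.15 log units; that floor lies within the scatter) at most. The estimate for compound 4 in this assay is 70000 nM, in a range from 25000 nM to 200000 nM.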

Compound 4, half-maximal cytotoxic concentration: 3800 nM
Compound 4: the middle estimate sits 18-fold (1.27 log units) above what was measured; the whole stated range lies above it.
By their numbers in this assay, from the lowest: compound 4; then compounds 2 and 1 (each within the scatter of the next). At a limit, above all of these: compound 3.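

On the aromatic carbon ortho to the ((pyridin-4-yl)oxy)methyl group, chloro in place of hydrogen gives an at least 26-fold lower number from compound 3 to compound 4 (1.42 log units; beyond the scatter) in this assay, a change that the earlier step, which stayed within the scatter, did not cover. With the chloro group kept, the other group on that ring also matters, since ((pyridin-4-yl)oxy)methyl in place of pyridin-3-yl gives a 2.3-fold lower number from compound 2 to compound 4 (0.37 log units; beyond the scatter) and in place of (pyridin-3-yl)oxy gives a 4.2-fold lower number from compound 1 to compound 4 (0.62 log units; beyond the scatter). Compound 3 stands at a limit and not at a number, so the chloro step is only a floor: the limit of > 100000 nM in this assay, at which 1 of the 4 values shown sits.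

Going by these compounds, it remains open whether a fluoro or methyl group on the same carbon would lower the number as chloro does. On these data alone, it also remains open whether the chloro step would hold with (pyridin-3-yl)oxy or pyridin-3-yl in place of ((pyridin-4-yl)oxy)methyl.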